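The source may report more compounds than this note shows. Statements on the series, on what has been measured and on what is new or still open speak of the compounds shown alone.

Measured compounds:
- compound 1, `C=C(Br)C(=O)Nc1cccc(/C=C2\SC(=O)N(Cc3ccc(Cl)cc3)C2=O)c1`, 1600 nM
- compound 2, `C=C(Br)C(=O)Nc1ccc(/C=C2\SC(=O)N(Cc3cccc(F)c3)C2=O)cc1`, 4000 nM
- compound 3, `C=C(Br)C(=O)Nc1ccc(/C=C2\SC(=O)N(Cc3cccc(Cl)c3)C2=O)cc1`, 6100 nM

These three share one core and were tested in a functional assay on FM3A cells (Mus musculus) for cytotoxicity, read by cell counting, with a stated time of 2 days; on this read-out lower numbers stand for stronger inhibition and higher numbers for weaker inhibition. Compound 3 gives a number that is within the scatter of what compound 2 gives, while compound 1 gives a number that lies beyond the scatter on the lower side. Among the compounds with values here, the only single-point step among the measured compounds is a 1.5-fold higher number from compound 2 to compound 3 (0.18 log units; within the scatter).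

Compound 4, `C=C(Br)C(=O)Nc1ccc(/C=C2\SC(=O)N(Cc3ccc(C)cc3)C2=O)cc1`, has not yet been tested in this assay. It differs from compound 3 in one place: 4-methylphenyl in place of 3-chlorophenyl on a saturated chain carbon bound to an amide-type nitrogen in a ring. Within the data shown here, no measured pair shows this same exchange, and the one measured step concerns a different exchange on the same ring, so it only suggests that changes on this ring have so far stayed within the scatter. On that basis no step beyond the scatter is expected, and the estimated step for compound 4 is a 1.2-fold lower number from compound 3 to compound 4 (0.09 log units; within the scatter). Compound 4 is therefore expected to give 5000 nM in this assay, within a range from 2000 nM to 15000 nM.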

Compound 4, half-maximal inhibitory concentration: 6100 nM
Compound 4: middle estimate off by 1.2-fold (0.09 log units), on the low side; low and high end bracket the measured number.
By their numbers in this assay, from the lowest: compound 1; then compounds 2, 3 and 4 (each within the scatter of the next).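

In this assay the exchange of 3-chlorophenyl for 4-methylphenyl gives no change at the digits printed from compound 3 to compound 4 (within the scatter) and the matching exchange from 3-fluorophenyl gives a 1.5-fold higher number from compound 2 to compound 4 (0.18 log units; within the scatter) at this place on a saturated chain carbon bound to an amide-type nitrogen in a ring. Within the data shown here, earlier, the only step at this place was one halogen for another; among compounds 2, 3 and 4, a ring carrying methyl and no halogen also stays within the scatter. No available information explains this result.

This exchange alters both the substituent and its location on the aromatic ring, and compounds 2, 3 and 4 do not separate those two changes. From the compounds shown here alone, whether an amine, a carboxylic acid or a longer chain in place of the benzyl group would move the number beyond the scatter remains open.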